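This account rests on a few compounds, and the source may have more. Where it says the series, first, only, none or still open, it means among the compounds named here.

Measured so far:
compound 1, `COc1cc(C(=O)Nc2nn[nH]n2)nc(-c2ccc(C)cc2)c1`: 16%
compound 2, `CCCOc1cc(C(=O)Nc2nn[nH]n2)nc(-c2ccc(N)cc2)c1`: 7%
compound 3, `CCN(CC)c1ccc(-c2cc(C)cc(C(=O)Nc3nn[nH]n3)n2)cc1`: 19%

In a functional assay on the whole organism for inhibition, with Rattus norvegicus as the target, at a dose of 0.3 mg/kg by the oral route (on this read-out lower numbers stand for a weaker effect and higher numbers for a stronger effect at the one dose given), compound 2 stands lowest of the three numbers. Compound 1 lies within the scatter of compound 2, so the two cannot be ordered; compound 3 lies beyond the scatter of compound 2 and gives the stronger effect of that pair.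

Compound 4, `CC(C)c1cc(C(=O)Nc2nn[nH]n2)nc(-c2ccc(N)cc2)c1`, has not been measured. It differs from compound 2 by isopropyl in place of propoxy on an aromatic carbon. Within the data shown here, no measured pair shows this change, so nothing in these data tells how large its effect is. Compound 4 is therefore expected to give a number within the scatter of compound 2, an estimated step of a number 3 percentage points higher from compound 2 to compound 4 (within the scatter) in this assay. Compound 4 is estimated at 10%, in a range from 0% to 25%.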

Compound 4, a percentage reported as inhibition, in the whole organism at one dose (the size of the read-out at that dose, not a potency): 22%
Compound 4: middle estimate off by 12 percentage points, on the low side, within the range that was stated.
By their numbers in this assay, from the lowest: compounds 2, 1, 3 and 4 (each within the scatter of the next, the first and the last beyond it).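

In this assay, isopropyl in place of propoxy on the aromatic carbon opposite the ring nitrogen gives a number 15 percentage points higher from compound 2 to compound 4 (beyond the scatter) and so shows that the read-out responds to the group at this position. Among these compounds, this is the first single change that can be read. Nothing on hand accounts for the step. The compounds shown leave open how an ethyl, a tert-butyl or a cyclopropyl group would read at this position with the 4-aminophenyl group kept. They also leave open whether the same change gives a similar step with another aryl group.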